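A Hydroxybutyl Chain in Place of a Butanamide Group

A few compounds are considered here, and "the series" means these few. Any claim that something is new, unique, unknown or untested is made for them only; others in the source may bear on it.

Of the compounds shown here, two of a shared core have been measured so far. Compound 1 `COc1ccc(-c2cnc(N)nc2-c2ccccc2)cc1OC` gives, in an assay on CHO cells for displacement of a labelled ligand from adenosine receptor A1 (Homo sapiens), read by scintillation counting, with a stated time of 1 h (a higher number here means a weaker inhibitor, a lower number a stronger inhibitor), a value of 104 nM. Compound 2 `CCCC(=O)Nc1ncc(-c2cccc(Cl)c2)c(-c2ccccc2)n1` gives, in this assay, a value of 106 nM. Compound 2 has the higher of the two numbers, but the gap to compound 1 is so small that it falls within the ordinary scatter of repeated measurements, so the two compounds cannot be told apart on these data.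

Compound 3 `OCCCCNc1ncc(-c2cccc(Cl)c2)c(-c2ccccc2)n1` has not yet been measured. It differs from compound 2 in one place: 4-hydroxybutyl in place of propylcarbonyl on a nitrogen on an aromatic ring. In words, an amide becomes a plain amine carrying a chain that ends in a hydroxyl group. Among the measured compounds shown here, no measured pair in this set shows what such a change does, so there is no direct precedent to lean on.

The expectation is a modest rise in the number, perhaps not clearly beyond the scatter, as the step of a 1.9-fold higher number from compound 2 to compound 3 (0.28 log units; within the scatter). Compound 3 is therefore estimated at 200 nM in this assay, with a plausible range from 50 nM to 800 nM.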

Compound 3, inhibition constant: 130 nM
The estimate for compound 3 lay 1.5-fold (0.19 log units) above the measured number; the range from low to high includes it.
By their numbers in this assay, from the lowest: compounds 1, 2 and 3 (each within the scatter of the next).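

In this assay, the change at this position gives a 1.2-fold higher number from compound 2 to compound 3 (0.09 log units; within the scatter), which lies within the usual scatter, so compound 2 and compound 3 cannot be told apart on these data. Among the compounds shown here, this is the first pair in the set that isolates a single change, and it shows that, as far as this measurement can tell, the amide need not be kept at this nitrogen on an aromatic ring: 4-hydroxybutyl, with a hydrogen-bond donor that propylcarbonyl lacks and without the double bond that propylcarbonyl carries, can stand in its place with no change that can be detected. Nothing available here bears on what lies behind this result.

As far as these compounds go, a single pair cannot show how much this position tolerates, so it remains open whether a shorter or longer chain ending in a hydroxyl group, or a chain ending in an amine or a carboxylic acid, would also leave the number within the scatter. From the compounds shown here alone, it also remains open whether the same change would read alike on the core of compound 1.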